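Cytotoxicity notes: amide change from compound 1 to compound 3

The source may hold more compounds than are shown below. What is called first, only, known or untested is meant among the compounds shown, and "the series" means these compounds.

Compound 1 `Cc1ccc(C(=O)Nc2cc3nc(C4CCCCC4)[nH]c3cc2N2CCCC2)cc1`: in an ADME assay on Vero cells (Chlorocebus sabaeus) for cytotoxicity, read by resazurin assay, with a stated time of 3 days (a higher number here means a weaker inhibitor, a lower number a stronger inhibitor), compound 1 gives only a limit of the assay, > 100 ug/mL.
Compound 2 `CCN(CC)c1cc2[nH]c(C3CCCCC3)nc2cc1NC(=O)c1ccc(C)cc1`: in this assay compound 2 likewise gives only a limit, > 100 ug/mL.

Among the compounds with values here, compound 1 stands at the limit of this assay and nowhere else on the numbers; its only measured neighbour, compound 2, sits at the same limit. Within the data shown here, the one measured step, a step that the two limits leave unreadable from compound 1 to compound 2, is therefore unreadable, the pair of limits giving no size and no direction. Both values rest on (the limit of > 100 ug/mL in this assay, at which 2 of the 2 values shown sit).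

Compound 3 `CCCCCC(=O)Nc1cc2nc(C3CCCCC3)[nH]c2cc1N1CCCC1` differs from compound 1 by pentyl in place of 4-methylphenyl on a carbonyl carbon. Among the measured compounds shown here, no measured step touches this place: the step known concerns the amino group on the aromatic carbon, not the carbonyl substituent, and is itself unreadable. There is thus nothing in the numbers to anchor a step of any size. The expectation is that compound 3 again reaches only the limit, so that a step that the limit leaves unreadable from compound 1 to compound 3 is expected to stay within the scatter. Compound 3 is estimated at 120 ug/mL, with a range from 50 ug/mL to 300 ug/mL, most likely reported as a limit.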

Compound 3, half-maximal inhibitory concentration: > 100 ug/mL
Compound 3: a limit, no number; the forecaster's own chance of this, stated with the estimate: 75%; the middle value is on the limit's open side.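

No step can be read between compound 1 and compound 3, as both give only a limit in this assay: the limit of > 100 ug/mL in this assay, at which 3 of the 3 values shown sit.

Compound 1, compound 2 and compound 3 leave open whether exchanging pentyl for 4-methylphenyl on the carbonyl carbon, or diethylamino for pyrrolidin-1-yl on the aromatic carbon, changes cytotoxicity at all.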